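The compounds below may be only part of what the source reports. "The series", "measured", "known", "first", "only" and "open" are said of these compounds alone.

Measured in an assay on microsomes from intestine for inhibition of acyl-CoA:cholesterol acyltransferase (Oryctolagus cuniculus); on this read-out higher numbers stand for weaker inhibition and lower numbers for stronger inhibition:
compound 1 `Cc1cc(C)c(NC(=O)N(Cc2ccc(-c3nnc(C)o3)cc2)C2CCCCCC2)c(C)c1` — 27 nM
compound 2 `Cc1cc(C)c(NC(=O)N(Cc2ccc(-c3ccccn3)cc2)C2CCCCCC2)c(C)c1` — 33 nM
compound 3 `Cc1cc(C)c(NC(=O)N(Cc2ccc(-n3cccn3)cc2)C2CCCCCC2)c(C)c1` — 70 nM

Compound 3 stands at the highest number of the three in this assay. The step of a 2.6-fold higher number from compound 1 to compound 3 (0.41 log units; beyond the scatter) and the step of a 2.1-fold higher number from compound 2 to compound 3 (0.33 log units; beyond the scatter) both lie beyond the scatter, while the step of a 1.2-fold higher number from compound 1 to compound 2 (0.09 log units; within the scatter) does not. Two of the three groups at this position thus give close numbers, and the 1H-pyrazol-1-yl of compound 3 gives a modestly higher one.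

Compound 4 `Cc1cc(C)c(NC(=O)N(Cc2ccc(-c3cnn(C)c3)cc2)C2CCCCCC2)c(C)c1` is not yet measured. The change is 1-methyl-1H-pyrazol-4-yl in place of 1H-pyrazol-1-yl on an aromatic carbon. Among the compounds with values here, no measured step covers this exact exchange; the steps that bear on it are the two other exchanges at the same place, a 2.6-fold higher number from compound 1 to compound 3 (0.41 log units; beyond the scatter) and a 2.1-fold higher number from compound 2 to compound 3 (0.33 log units; beyond the scatter), both modest. Read in reverse, leaving the 1H-pyrazol-1-yl for another group at this position has so far moved the number back toward those of compound 1 and compound 2. For compound 4 a step of similar size toward a lower number, or none beyond the scatter, is therefore expected in this assay. The estimate for compound 4 is 40 nM, in the range 15 nM to 100 nM. This corresponds to an expected step of a 1.8-fold lower number from compound 3 to compound 4 (0.24 log units; within the scatter).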

Compound 4, half-maximal inhibitory concentration: 47 nM
Compound 4: the middle estimate sits 1.2-fold (0.07 log units) below what was measured; the measured number falls inside the stated range.
By their numbers in this assay, from the lowest: compounds 1, 2, 4 and 3 (each within the scatter of the next, the first and the last beyond it).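

In this assay, the exchange of 1H-pyrazol-1-yl for 1-methyl-1H-pyrazol-4-yl gives a 1.5-fold lower number from compound 3 to compound 4 (0.17 log units; within the scatter), so these two pyrazoles, which differ in the atom of attachment and in one methyl, are not separated at this position. Compound 4 also lies within the scatter of the other two groups, with a 1.4-fold higher number from compound 2 to compound 4 (0.15 log units; within the scatter) and a 1.7-fold higher number from compound 1 to compound 4 (0.24 log units; within the scatter), so a pyrazole at this place need not stand apart from the pyridin-2-yl and the 5-methyl-1,3,4-oxadiazol-2-yl, as the 1H-pyrazol-1-yl of compound 3 does; the numbers now form a continuous run in which only the two ends, and compound 2 with compound 3, lie beyond the scatter of each other. No measurement at hand accounts for these numbers.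

The compounds shown do not separate the added methyl from the change in attachment, and 1H-pyrazol-4-yl without the methyl would bear on that. On these data alone, all four groups are neutral aromatic rings, so it stays open how the position responds to a carboxylic acid, a dimethylamino group or a saturated ring such as morpholine.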